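Swapping Isopropyl for Oxetane on a Ring Nitrogen

A few compounds are considered here, and "the series" means these few. Any claim that something is new, unique, unknown or untested is made for them only; others in the source may bear on it.

Among the compounds with values here, compound 2 `COc1nn(C)c2nc(NC(C)C)nc(NS(=O)(=O)c3cccc(Cl)c3Cl)c12` sits at the higher of the two numbers so far: in a functional assay on cells for antagonist activity at C-C chemokine receptor type 4 (Homo sapiens), read by GTPgammaS binding (on this read-out lower numbers stand for stronger inhibition and higher numbers for weaker inhibition), compound 2 gives 3160 nM, while compound 1 `COc1nn(C)c2nc(N)nc(NS(=O)(=O)c3cccc(Cl)c3Cl)c12` gives 316 nM. The single step shown, a 10-fold higher number from compound 1 to compound 2 (1.00 log units; beyond the scatter), put isopropyl where hydrogen had been. Compound 3 `COc1nn(C)c2nc(NC3COC3)nc(NS(=O)(=O)c3cccc(Cl)c3Cl)c12` changes that same place again: oxetan-3-yl in place of isopropyl on a nitrogen on an aromatic ring. No measured step tests this exchange directly; the one step shown says a group on this nitrogen raised the number, and oxetan-3-yl keeps a group of similar size there. The expected step is a 1.3-fold lower number from compound 2 to compound 3 (0.10 log units; within the scatter), not beyond the scatter. Compound 3 is estimated at 2500 nM, between 800 nM and 8000 nM.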

Compound 3, half-maximal inhibitory concentration in the C-C chemokine receptor type 4 assay: 10000 nM
Compound 3: middle estimate off by 4.0-fold (0.60 log units), on the low side; the whole stated range lies below it.
By their numbers in the C-C chemokine receptor type 4 assay, from the lowest: compound 1; then compound 2; then compound 3.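

In the C-C chemokine receptor type 4 assay, oxetan-3-yl on this nitrogen gives a 3.2-fold higher number from compound 2 to compound 3 (0.50 log units; beyond the scatter), and against the unsubstituted amine it gives a 32-fold higher number from compound 1 to compound 3 (1.50 log units; beyond the scatter). So inhibition depends on which group sits here, not only on whether a group is present. In a physicochemical assay for lipophilicity (a lower number here means a more polar compound, a higher number a more lipophilic compound), compound 2 gives 5.2 and compound 3 gives 2.2 as its value. The exchange for isopropyl also makes the compound much more polar, and here the more polar compound is the weaker inhibitor: the measured distribution coefficient of compound 2, 5.2, and of compound 3, 2.2, a number 3.00 log units lower (beyond the scatter)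

One pair cannot tell whether the oxygen or the ring accounts for the weaker inhibition. As far as these compounds go, whether a cyclobutyl or methyl group would bring the number closer to that of compound 1 stays open.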